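This account rests on a few compounds, and the source may have more. Where it says the series, first, only, none or still open, it means among the compounds named here.

Measured in a functional assay on K562 cells (Homo sapiens) for antiproliferative activity, read by MTT assay, with a stated time of 24 h; on this read-out higher numbers stand for weaker inhibition and lower numbers for stronger inhibition:
- compound 1 `CCN(CC)c1ccc(/C=C/C(=O)c2ccc(OC)c3c2OC(C)(C)C=C3)cc1`: 790 nM
- compound 2 `COc1ccc(C(=O)/C=C/c2ccc(-n3ccnc3)cc2)c2c1C=CC(C)(C)O2`: > 10000 nM (a limit of the assay)
- compound 3 `COc1ccc(C(=O)/C=C/c2ccccn2)c2c1C=CC(C)(C)O2`: 5400 nM

Of the two numbers, compound 3 at 5400 nM stands higher, while compound 1 gives 790 nM, a gap beyond the scatter. Compound 2 gives only a limit, > 10000 nM.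

Compound 4 `COc1ccc(C(=O)/C=C/c2ccc(O)cc2)c2c1C=CC(C)(C)O2` differs from compound 3 as follows: 4-hydroxyphenyl in place of pyridin-2-yl on a double-bonded chain carbon bound to a double-bonded chain carbon. Going by the values given here, only one measured step bears on this, and only indirectly: an at least 12-fold higher number from compound 1 to compound 2 (1.10 log units; beyond the scatter). That step is large, but it swaps a group on an aromatic carbon and leaves the ring itself in place, so it sets no size for this change. In this assay the expected change is small, towards lower numbers and not beyond the scatter: a 1.5-fold lower number from compound 3 to compound 4 (0.19 log units; within the scatter). For compound 4 the estimate is 3500 nM, expected within 1000 nM to 10000 nM.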

Compound 4, half-maximal inhibitory concentration: > 10000 nM
Compound 4 gave a limit, no number; the forecaster's own chance of this, stated with the estimate: 15%; middle value at least 2.8-fold (0.45 log units) away from the limit.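

In this assay, 4-hydroxyphenyl in place of pyridin-2-yl on a double-bonded chain carbon gives an at least 1.8-fold higher number from compound 3 to compound 4 (0.26 log units; that floor lies within the scatter), so the direction is towards higher numbers, but the floor alone does not establish a real change. Hydroxy in place of diethylamino on an aromatic carbon gives an at least 12-fold higher number from compound 1 to compound 4 (1.10 log units; beyond the scatter), a second large step away from the diethylamino compound. The step between compound 2 and compound 4 cannot be read, since both values are limits: the limit of > 10000 nM in this assay, at which 2 of the 4 values shown sit.

Still open, as far as these compounds go, is whether a smaller amine such as dimethylamino, or a longer chain on that nitrogen, keeps the number of compound 1. From the compounds shown here alone, how a carboxylic acid on the aromatic carbon would read also remains open.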